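This account rests on a few compounds, and the source may have more. Where it says the series, first, only, none or still open, it means among the compounds named here.

Of the compounds shown here, three have numbers so far in a functional assay with Homo sapiens as the target; on this read-out higher numbers stand for weaker inhibition and lower numbers for stronger inhibition. Compound 1 (`CCN(CC)CCCCNc1nc2cc(Cl)c(Cl)cc2nc1-c1ccc(-c2cccs2)s1`) gives 170 nM, compound 2 (`O=C(Nc1ccccc1O)c1ccc(Cl)[n+]([O-])c1`) gives 4200 nM, and compound 3 (`CC(C)S(=O)(=O)c1ccc(C(=O)Nc2ccc(F)cc2)c[n+]1[O-]`) gives 2000 nM. Compound 3 therefore sits in the middle of the three. Its inhibition is stronger than that of compound 2 by a small margin that still lies beyond the usual scatter, and clearly weaker than that of compound 1.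

Compound 4 (`O=C(Nc1ccc(F)cc1)c1ccc(S(=O)(=O)Cc2ccccc2)[n+]([O-])c1`) is compound 3 with benzyl in place of isopropyl on a sulfonyl sulfur. Within the data shown here, no two measured compounds differ in only one place, so the data offer no direct guide to this swap. A modest step toward stronger inhibition is expected in this assay, about the size of the scatter or a little more, but this is a tentative judgement and the true step could go either way. The estimated step is a 2.2-fold lower number from compound 3 to compound 4 (0.35 log units; beyond the scatter). The estimate for compound 4 is 900 nM, with an expected range from 250 nM to 3000 nM.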

Compound 4, half-maximal inhibitory concentration: 1000 nM
Estimate against measurement, compound 4: 1.1-fold (0.05 log units) below; the measured number falls inside the stated range.
By their numbers in this assay, from the lowest: compound 1; then compounds 4 and 3 (each within the scatter of the next); then compound 2.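

Among these compounds, compounds 3 and 4 are the first pair here that differ in only one place, and in this assay the swap gives a 2.0-fold lower number from compound 3 to compound 4 (0.30 log units; within the scatter) with benzyl in place of isopropyl on a sulfonyl sulfur. This position therefore takes a group of 7 heavy atoms with a six-membered aromatic ring where one of 3 heavy atoms stood, and the two compounds cannot be told apart on this read-out. Nothing measured here speaks to the reason for this result.

As far as these compounds go, whether a methyl, a saturated cyclohexyl ring, or a benzyl carrying an amine or a carboxylic acid would also hold the number in this range remains open. One pair also cannot show whether the same swap would behave alike on any other core.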